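A few compounds are considered here, and "the series" means these few. Any claim that something is new, unique, unknown or untested is made for them only; others in the source may bear on it.

Measured compounds and their values:

Compound 1 `C/C=C1/[C@H](O[C@@H]2O[C@H](COC(C)=O)[C@@H](OC(C)=O)[C@H](OC(C)=O)[C@H]2OC(C)=O)OC=C(C(=O)OC)[C@H]1CC(=O)O`. In a functional assay on SK-BR-3 cells (Homo sapiens) for antiproliferative activity, read by MTT assay, with a stated time of 72 h (a lower number here means a stronger inhibitor, a higher number a weaker inhibitor), compound 1 gives > 15000 nM, which is a limit of the assay and not a number.

Compound 2 `C/C=C1/[C@H](O[C@@H]2O[C@H](CO)[C@@H](O)[C@H](O)[C@H]2O)OC=C(C(=O)OC)[C@H]1CC(=O)OCCc1ccc(OC)c(OC)c1`. In this assay compound 2 gives > 15000 nM, again only a limit.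

Compound 3 `C/C=C1/[C@H](O[C@@H]2O[C@H](COC(C)=O)[C@@H](OC(C)=O)[C@H](OC(C)=O)[C@H]2OC(C)=O)OC=C(C(=O)O)[C@H]1CC(=O)O`. In this assay compound 3 gives > 20000 nM, also a limit.

Compound 1 therefore stands at the limit of > 15000 nM in this assay, at which 2 of the 3 values shown sit, and it cannot be placed in any order among the three, since every value shown is a limit; compound 3 sits at the limit of > 20000 nM in this assay, at which 1 of the 3 values shown sits. Among the compounds with values here, the single measured step, a step that the two limits leave unreadable from compound 1 to compound 3, is left unreadable by the two limits, so no size can be drawn from it.

Compound 4 `C/C=C1/[C@H](O[C@@H]2O[C@H](COC(C)=O)[C@@H](OC(C)=O)[C@H](OC(C)=O)[C@H]2OC(C)=O)OC=C(C(=O)OC)[C@H]1CC(=O)OCCCC` differs from compound 1 by butyl in place of hydrogen on an oxygen next to a carbonyl group. Within the data shown here, no measured step touches this kind of change, and the one step that is measured gives no number. What the three values do show is that none of them reaches a readable inhibition, and nothing among them suggests that compound 4 would. Compound 4 is therefore expected to remain at the limit, with an estimate of 20000 nM and a range from 8000 nM to 60000 nM. The step that the limit leaves unreadable from compound 1 to compound 4 is expected to be none beyond the scatter, and most likely not readable at all.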

Compound 4, half-maximal inhibitory concentration: > 15000 nM
Compound 4: a limit, no number; the forecaster's own chance of this, stated with the estimate: 80%; the middle value does not contradict the limit.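

In this assay compound 4 gives > 15000 nM, which is a limit and not a number. Within the data shown here, compound 1 also stands at a limit, so no step from compound 1 to compound 4 can be read. The compounds shown leave open whether butyl in place of hydrogen there changes activity at all, and whether any change to the shared core gives a readable value.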